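The source may report more compounds than this note shows. Statements on the series, on what has been measured and on what is new or still open speak of the compounds shown alone.

Measured so far:
compound 1 `Cc1ccc(C(CCCCNC(=O)Nc2ccc(Cl)c(C(F)(F)F)c2)c2ccc(C)cc2)cc1`, "not determined" (no result reported) in an ADME assay on isolated protein for inhibition of sodium-dependent dopamine transporter (Homo sapiens); a higher number here means a weaker inhibitor, a lower number a stronger inhibitor;
compound 2 `COc1ccc(C(CCCCNC(=O)Nc2ccc(Cl)c(C(F)(F)F)c2)c2ccc(OC)cc2)cc1`, 40 nM in this assay.

Within the data shown here, compound 2 thus holds the only number recorded in this assay, since compound 1 carries no result for its inhibition constant. Compound 3 `COc1ccc(C(CCCCNC(=O)Nc2ccc(Cl)c([N+](=O)[O-])c2)c2ccc(OC)cc2)cc1` differs from compound 2 by nitro in place of trifluoromethyl on an aromatic carbon. Among the measured compounds shown here, no step between two measured compounds has been recorded, so nothing shows how far such a swap moves the inhibition constant. One expects the step of a 1.3-fold higher number from compound 2 to compound 3 (0.10 log units; within the scatter) to stay within the usual scatter, with at most a slight lean toward a weaker inhibitor. For compound 3 the estimated inhibition constant is 50 nM, with a range from 15 nM to 160 nM.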

Compound 3, inhibition constant: 144 nM
Compound 3: the middle estimate sits 2.9-fold (0.46 log units) below what was measured; measured number inside the range.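

Placed on the aromatic carbon ortho to the chloro group, nitro does not stand in for trifluoromethyl without cost in this assay: the swap gives a 3.6-fold higher number from compound 2 to compound 3 (0.56 log units; beyond the scatter), a modest step but one beyond the scatter. This first recorded step shows that the inhibition constant responds to the group at this position, and here trifluoromethyl gives the stronger inhibitor. Nothing available explains the difference. Still open, on these data alone, is how a nitrile, an amine or a carboxylic acid would compare at this position, and whether the step holds with other groups on the shared core.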